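The source may report more compounds than this note shows. Statements on the series, on what has been measured and on what is new or still open speak of the compounds shown alone.

Among the compounds with values here, compound 1 `O=C(NOCc1ccccc1)Nc1ccc2c(-c3ccncc3)c[nH]c2c1` and compound 2 `Cn1cc(C#N)c2ccc(NC(=O)NOCc3ccccc3)cc21` are the two compounds with numbers so far. In a physicochemical assay for solubility, at pH 5 (a lower number here means a less soluble compound, a higher number a more soluble compound), compound 1 gives 17.5 ug/mL, the higher of the two, and compound 2 gives 4.5 ug/mL, a gap that lies beyond the scatter of repeated measurements. Compound 3 `CN(C(=O)Nc1ccc2c(-c3ccncc3)c[nH]c2c1)c1ccccc1` remains to be measured in this assay. It differs from compound 1 in one place: methyl(phenyl)amino in place of (benzyloxy)amino on a carbonyl carbon. The (benzyloxy)amino group leaves and methyl(phenyl)amino enters on the carbonyl carbon whose other neighbour is an amide-type nitrogen; the group that leaves carries one hydrogen-bond donor and one hydrogen-bond acceptor, the group that enters carries none of either. Within the data shown here, no pair of measured compounds differing in a single place is available, so the size of this step cannot be read from the data and can only be expected. For compound 3 the expectation is a downward step of a 2.2-fold lower number from compound 1 to compound 3 (0.34 log units; beyond the scatter) in this assay, modest and close to the edge of the scatter. Compound 3 is therefore estimated at 8 ug/mL, with a range from 3 ug/mL to 22 ug/mL.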

Compound 3, solubility: 42 ug/mL
The estimate for compound 3 lay 5.3-fold (0.72 log units) below the measured number; measured number outside the range, above it.
By their numbers in this assay, from the lowest: compound 2; then compound 1; then compound 3.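

Within the data shown here, at the carbonyl carbon whose other neighbour is an amide-type nitrogen, the only step available in this assay runs upward: methyl(phenyl)amino in place of (benzyloxy)amino gives a 2.4-fold higher number from compound 1 to compound 3 (0.38 log units; beyond the scatter), modest in size but beyond the scatter. This shows that a change at this place can move the read-out on the shared core, and that here the number rises although the entering group carries neither the hydrogen-bond donor nor the hydrogen-bond acceptor counted on the leaving group, while both groups keep a six-membered aromatic ring of carbon only. No measurement shown here accounts for the rise.

The step changes several features of the group at once, so the compounds shown leave open how much of it belongs to each, and a benzylamino group or a plain phenylamino group would separate those contributions. Going by these compounds, compound 2 differs from compound 1 and compound 3 in more than one place, so it also remains open whether the same exchange would raise the number on the core of compound 2.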